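The compounds below may be only part of what the source reports. "The series", "measured", "known", "first", "only" and "open" are said of these compounds alone.

Measured compounds:
Compound 1 `COc1cc(/C=C/C(=O)/C=C/c2cc(OC)c(OC)c(OC)c2)ccc1OCc1cn(CCCCCOc2cc(=O)oc3ccccc23)nn1` gives "not active" (no number reported) in a functional assay on PC-3 cells (Homo sapiens) for inhibition, read by sulforhodamine B assay, with a stated time of 48 h, tested at 50 uM; on this read-out higher numbers stand for more inhibition of growth at the one concentration tested and lower numbers for less inhibition of growth.
Compound 2 `COc1cc(/C=C/C(=O)/C=C/c2cc(OC)c(OC)c(OC)c2)ccc1OCc1cn(CCCOc2cc(=O)oc3ccccc23)nn1` gives 12% in this assay.

Compound 1 and compound 2 share the same core and differ only in the length of the linking chain. Compound 1 has no single number in this assay: it was reported only as not active, so it stands at the low end without a figure to place it. Compound 2 shows only a small effect, so both measured compounds sit low in this assay.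

Compound 3 `COc1cc(/C=C/C(=O)/C=C/c2ccccc2)ccc1OCc1cn(CCCCCOc2cc(=O)oc3ccccc23)nn1` differs from compound 1 by phenyl in place of 3,4,5-trimethoxyphenyl on a double-bonded chain carbon bound to a double-bonded chain carbon. For the measured compounds named here, no measured pair shows this change, so no measured step guides it. In this assay a small step is expected, in either direction, and most likely none beyond the scatter, since compound 1 gives "not active" (no number reported) and compound 2 gives 12%. Compound 3 is therefore expected near 10%, with a range from 0% to 30%.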

Compound 3, percent growth inhibition at one concentration: "not active" (no number reported)
Compound 3: no number reported, so the estimate cannot be set against anything.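

In this assay compound 1 gives "not active" (no number reported) and compound 3 gives "not active" (no number reported) and so no step can be read between them. No supporting data bear on this result. The compounds shown leave open whether replacing 3,4,5-trimethoxyphenyl with phenyl changes growth inhibition at all.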